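Compound 3 to compound 4: removing the ring

The source may report more compounds than this note shows. Statements on the series, on what has been measured and on what is new or still open speak of the compounds shown alone.

Measured in an ADME assay on the whole organism (strain CD-1) for pharmacokinetics, with Mus musculus as the target, at a dose of 3 mg/kg by the intravenous route; a lower number here means slower removal, a higher number faster removal of the compound
Compound 1 `CC(CCCCOc1ccccc1CN(C)C(=O)c1ccc(-c2ccco2)cc1)C(=O)O` gives 3 mL/min/kg
Compound 2 `C[C@@H](CCCOc1ccccc1CN(C)C(=O)c1ccc(-c2ccco2)cc1)CC(=O)O` gives 1.3 mL/min/kg
Compound 3 `CN(Cc1ccccc1OCCC[C@@H]1C[C@H]1C(=O)O)C(=O)c1ccc(-c2ccco2)cc1` gives 0.6 mL/min/kg

Compound 3 has the lowest number of the three (0.6 mL/min/kg). Compound 4 `CC(CCOc1ccccc1CN(C)C(=O)c1ccc(-c2ccco2)cc1)CCC(=O)O` carries 3-carboxy-1-methylpropyl in place of (2-carboxycyclopropyl)methyl on a saturated chain carbon, two bonds along the chain from an oxygen on an aromatic ring. It therefore has no three-membered ring, as is also the case for compound 1 and compound 2. Going by the values given here, two measured steps bear most directly on this change, both with 2-carboxycyclopropyl entering: a 5.0-fold lower number from compound 1 to compound 3 (0.70 log units; beyond the scatter) and a 2.2-fold lower number from compound 2 to compound 3 (0.34 log units; beyond the scatter). The two ringless compounds also differ from each other, a 2.3-fold lower number from compound 1 to compound 2 (0.36 log units; beyond the scatter), so the size of the reverse step remains uncertain. A step of comparable size towards a higher number is therefore expected in this assay. The expected change is a 3.3-fold higher number from compound 3 to compound 4 (0.52 log units; beyond the scatter). The estimate for compound 4 is 2 mL/min/kg, with an expected range of 0.9 mL/min/kg to 4.5 mL/min/kg.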

Compound 4, clearance: 4 mL/min/kg
Estimate against measurement, compound 4: 2.0-fold (0.30 log units) below; the measured number falls inside the stated range.
By their numbers in this assay, from the lowest: compound 3; then compound 2; then compounds 1 and 4 (each within the scatter of the next).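

In this assay, swapping (2-carboxycyclopropyl)methyl for the ringless 3-carboxy-1-methylpropyl group removes the three-membered ring and raises the number (a 6.7-fold higher number from compound 3 to compound 4 (0.82 log units; beyond the scatter)). Losing the ring is not the whole story, since two ringless compounds also separate: the shift of the methyl and carboxylic acid along the chain gives a step beyond the scatter (a 3.1-fold higher number from compound 2 to compound 4 (0.49 log units; beyond the scatter)). Another ringless rearrangement stays within the scatter (a 1.3-fold higher number from compound 1 to compound 4 (0.12 log units; within the scatter)), so compound 2 goes against any simple reading in which all ringless chains behave alike.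

Going by these compounds, whether a four-membered carbon ring or a longer chain would keep the number as low as that of compound 3 stays open. Nothing shown here explains why these chains differ in how fast they are removed.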